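Changing the side chain from hydroxymethyl to carboxy

The source may report more compounds than this note shows. Statements on the series, on what has been measured and on what is new or still open speak of the compounds shown alone.

Measured in a functional assay on HeLa cells (Homo sapiens) for cytotoxicity, read by MTT assay; a higher number here means a weaker inhibitor, a lower number a stronger inhibitor
- compound 1 `COC(=O)C[C@@H]1C[C@@H](O)[C@H](C)[C@H](c2ccccc2)N1` gives 6500 nM
- compound 2 `C[C@H]1[C@H](O)C[C@@H](CCO)N[C@H]1c1ccccc1` gives 31500 nM

Of these two compounds, compound 2 has the higher number and is therefore the weaker inhibitor, with its gap to compound 1 lying beyond the usual scatter. The open question is compound 3 `C[C@H]1[C@H](O)C[C@@H](CC(=O)O)N[C@H]1c1ccccc1`, which carries carboxy in place of hydroxymethyl on a saturated chain carbon bound to a saturated ring carbon. Among the compounds with values here, the only measured step at this place is a 4.8-fold higher number from compound 1 to compound 2 (0.69 log units; beyond the scatter), a modest change with hydroxymethyl in place of methoxycarbonyl. Within the data shown here, it shows that a change here can shift the number in this assay, but no compound with carboxy has been measured. Carboxy and methoxycarbonyl are different groups, so that step cannot simply be run backwards, and it gives no firm direction. No shift beyond the scatter is therefore expected, though the uncertainty is wide. The expected change is a 1.1-fold lower number from compound 2 to compound 3 (0.02 log units; within the scatter), which is only an estimate. Compound 3 is estimated at 30000 nM (expected range 10000 nM to 100000 nM).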

Compound 3, half-maximal inhibitory concentration: 33400 nM
Compound 3: middle estimate off by 1.1-fold (0.05 log units), on the low side; the measured number falls inside the stated range.
By their numbers in this assay, from the lowest: compound 1; then compounds 2 and 3 (each within the scatter of the next).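

In this assay, replacing the 2-hydroxyethyl chain of compound 2 with the carboxymethyl chain of compound 3 gives a 1.1-fold higher number from compound 2 to compound 3 (0.03 log units; within the scatter), so on a saturated chain carbon bound to a saturated ring carbon, this assay does not separate hydroxymethyl from carboxy. The earlier step showed only that moving from methoxycarbonyl to hydroxymethyl raises the number; the new step, removing just the methyl of methoxycarbonyl to leave carboxy, gives a 5.1-fold higher number from compound 1 to compound 3 (0.71 log units; beyond the scatter), so compound 1 now stands apart from both of the other compounds, each by a step beyond the scatter. Among these three compounds, then, the lower number belongs only to the compound with methoxycarbonyl, and no supporting measurement is available to explain this difference.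

As far as these compounds go, what remains open is whether the lower number depends on methoxycarbonyl specifically or would also appear with a related group, such as ethoxycarbonyl or an amide. A primary amine or a longer chain at this place could also show whether the side chain can move the number further in either direction.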